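A few compounds are considered here, and "the series" means these few. Any claim that something is new, unique, unknown or untested is made for them only; others in the source may bear on it.

Measured so far:
compound 1 `Cn1c(Cc2nn(C)c(=O)c3ccccc23)nnc1SCCCCCCCCCCCCCCCC(=O)Nc1ccc(Cl)cc1Cl` — 7300 nM
compound 2 `Cn1c(Cc2nn(C)c(=O)c3ccccc23)nnc1SCCCCCCCC(=O)Nc1ccc(I)cc1` — 1300 nM
compound 3 `Cn1c(Cc2nn(C)c(=O)c3ccccc23)nnc1SCCCCCCCCCCC(=O)Oc1ccc(Cl)cc1Cl` — 8700 nM

In an assay on isolated protein (Mus musculus) for inhibition of IL15-IL15 receptor (Homo sapiens), read by resazurin assay, with stated times of 30 min and 2.5 days (on this read-out lower numbers stand for stronger inhibition and higher numbers for weaker inhibition), compound 2 gives the lowest of the three numbers; compound 1 and compound 3 both sit beyond the scatter above it. Compound 4 `CN(C(=O)CCCCCCCSc1nnc(Cc2nn(C)c(=O)c3ccccc23)n1C)c1ccc(Cl)cc1Cl` has not been measured. It differs from compound 2 by (2,4-dichlorophenyl)(methyl)amino in place of (4-iodophenyl)amino on a carbonyl carbon. Among the measured compounds shown here, no measured pair isolates this change, so the step can only be judged from what the numbers show: compound 1 and compound 3, which also carry the 2,4-dichlorophenyl group, give higher numbers than compound 2, though each differs from it in other respects as well. A step toward a higher number, beyond the scatter, is expected, a 2.7-fold higher number from compound 2 to compound 4 (0.43 log units; beyond the scatter). Compound 4 is estimated at 3500 nM, within a range of 1200 nM to 10000 nM.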

Compound 4, half-maximal inhibitory concentration: 11900 nM
Estimate against measurement, compound 4: 3.4-fold (0.53 log units) below; measured number above the stated range.
By their numbers in this assay, from the lowest: compound 2; then compounds 1, 3 and 4 (each within the scatter of the next).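

In this assay, the carbonyl carbon now has its first single-place comparison: (2,4-dichlorophenyl)(methyl)amino in place of (4-iodophenyl)amino gives a 9.2-fold higher number from compound 2 to compound 4 (0.96 log units; beyond the scatter) on an otherwise unchanged structure. The change removes the amide hydrogen and swaps the ring halogens in one step, so the two cannot be told apart here. No independent evidence explains the step.

As far as these compounds go, the share of the methyl on nitrogen and of the ring halogens remains open. (4-Iodophenyl)(methyl)amino on the same chain would separate them.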